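The source may hold more compounds than are shown below. What is called first, only, known or untested is meant among the compounds shown, and "the series" means these compounds.

Measured in a functional assay (mast cells) for inhibition, with Rattus norvegicus as the target; on this read-out higher numbers stand for an effect only at larger amounts of compound and lower numbers for an effect already at smaller amounts:
- compound 1 `C[C@H]1CCC(=NNc2ccccc2)c2ncc(C(=O)O)c(=O)n21`: 600 nM; 8000 nM (2 entries)
- compound 2 `CC1CC/C(=N\Nc2ccc(F)cc2)c2ncc(C(=O)O)c(=O)n21`: 1200 nM
- compound 3 `CC1CC/C(=N\Nc2cccc(Cl)c2)c2ncc(C(=O)O)c(=O)n21`: 311000 nM

Within the data shown here, compound 3 carries the highest single number so far, and compound 2 is its nearest neighbour. Compound 1 gives no single number, with entries of the several entries of compound 1 in this assay, 600 nM; 8000 nM (2 entries) that lie well apart. The unmeasured compound 4 `CC1CC/C(=N\Nc2ccc(Br)cc2)c2ncc(C(=O)O)c(=O)n21` differs from compound 3 by 4-bromophenyl in place of 3-chlorophenyl on an amine nitrogen and has 4-bromophenyl in place of 3-chlorophenyl on an amine nitrogen. Among the measured compounds shown here, no measured step makes this exact swap. The closest is a 260-fold higher number from compound 2 to compound 3 (2.41 log units; beyond the scatter) and this large step brought in the 3-chlorophenyl that now leaves. A large move back towards a lower number is therefore expected in this assay. The estimated change is a 78-fold lower number from compound 3 to compound 4 (1.89 log units; beyond the scatter) and it remains uncertain. Compound 4 is expected at 4000 nM with an estimated range from 600 nM to 60000 nM.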

Compound 4, half-maximal effective concentration: 2000 nM
For compound 4 the middle estimate is 2.0-fold (0.30 log units) above the measured one; measured number inside the range.
By their numbers in this assay, from the lowest: compounds 2 and 4 (each within the scatter of the next); then compound 3.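

The step to 4-bromophenyl on the amine nitrogen shows that the high number of compound 3 does not hold for every halogen-bearing phenyl here: in this assay there is a 160-fold lower number from compound 3 to compound 4 (2.19 log units; beyond the scatter). Bromo and fluoro on the aromatic carbon cannot be told apart, with a 1.7-fold higher number from compound 2 to compound 4 (0.22 log units; within the scatter), so of these three compounds only compound 3 stands apart.

That step changes both the halogen and its place, so 4-chlorophenyl or 3-bromophenyl would be needed to separate the two. The plain phenyl of compound 1 offers no firm reference: the several entries of compound 1 in this assay, 600 nM; 8000 nM (2 entries)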